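This account rests on a few compounds, and the source may have more. Where it says the series, first, only, none or still open, it means among the compounds named here.

Compound 2 `CCCC[C@]1(CC)CS(=O)(=O)c2ccc(C3CCNC3)cc2[C@@H](c2ccc(F)cc2)[C@H]1O` gives the higher of the two numbers measured in an assay on cells for inhibition of ileal sodium/bile acid cotransporter (Homo sapiens) (on this read-out lower numbers stand for stronger inhibition and higher numbers for weaker inhibition), namely 59 nM. Its nearest neighbour is compound 1 `CCCC[C@]1(CC)CS(=O)(=O)c2ccc(SC)cc2[C@@H](c2ccc(F)cc2)[C@H]1O`, which in this assay gives 19 nM. Among the compounds with values here, the single step between them, a 3.1-fold higher number from compound 1 to compound 2 (0.49 log units; beyond the scatter), is the only one that bears on what follows. Compound 3 `CCCC[C@]1(CC)CS(=O)(=O)c2ccc(C)cc2[C@@H](c2ccc(F)cc2)[C@H]1O` differs from compound 2 by methyl in place of pyrrolidin-3-yl on an aromatic carbon. That change removes the very group whose arrival raised the number from compound 1 to compound 2, and puts a small group in its place, much as compound 1 carries one. Because compound 1 gives 19 nM, the number for compound 3 is expected to move back down toward it, with a step of about a 2.4-fold lower number from compound 2 to compound 3 (0.37 log units; beyond the scatter) expected. For compound 3 the estimated value in this assay is therefore 25 nM, within a range from 8 nM to 80 nM.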

Compound 3, half-maximal inhibitory concentration: 21 nM
Estimate against measurement, compound 3: 1.2-fold (0.08 log units) above; low and high end bracket the measured number.
By their numbers in this assay, from the lowest: compounds 1 and 3 (each within the scatter of the next); then compound 2.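

In this assay replacing pyrrolidin-3-yl with methyl gives a 2.8-fold lower number from compound 2 to compound 3 (0.45 log units; beyond the scatter) and so sets compound 2 apart from two compounds with a small group at this aromatic carbon, where earlier there was only one. Methyl in place of methylsulfanyl gives a 1.1-fold higher number from compound 1 to compound 3 (0.04 log units; within the scatter) and leaves the two small groups indistinguishable, so the sulfur atom of compound 1 is not required for inhibition at this level. Nothing available here explains why the numbers fall this way.

The compounds shown leave open whether the higher number of compound 2 goes with the ring nitrogen or with the five-membered ring itself, which a cyclopentyl group or an open-chain amine at this carbon could separate. They also leave open how far the number depends on a group here at all, a question that a plain hydrogen would address.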